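Cyclopropyl for 4-methylphenyl on the amine, Vero cytotoxicity

A few compounds are considered here, and "the series" means these few. Any claim that something is new, unique, unknown or untested is made for them only; others in the source may bear on it.

Compound 1 `O=c1cc(OCC(O)CNC2CCCCC2)c2ccccc2o1` and compound 2 `Cc1ccc(NCC(O)COc2cc(=O)oc3ccccc23)cc1` share one core and differ only at an amine nitrogen. In an ADME assay on Vero cells (Chlorocebus sabaeus) for cytotoxicity, read by fluorescence and resazurin assay, with a stated time of 72 h (on this read-out lower numbers stand for higher toxicity in this test and higher numbers for lower toxicity in this test), compound 1 gives > 100000 nM, which is a limit of the assay rather than a number. In this assay compound 2 likewise gives > 100000 nM, also a limit. The step that the two limits leave unreadable from compound 1 to compound 2 cannot be read because both values sit at the limit (the limit of > 100000 nM in this assay, at which 2 of the 2 values shown sit). Compound 3 `O=c1cc(OCC(O)CNC2CC2)c2ccccc2o1` carries cyclopropyl in place of 4-methylphenyl on an amine nitrogen. No readable step bears on this change. The step that the limit leaves unreadable from compound 2 to compound 3 is therefore expected to be none beyond the scatter. Compound 3 is estimated at 150000 nM, between 70000 nM and 400000 nM.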

Compound 3, half-maximal cytotoxic concentration: > 100000 nM
Compound 3 was reported as a limit (the forecaster's own chance of this, stated with the estimate: 85%); the middle value lies beyond the limit too.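

No step among compound 1, compound 2 and compound 3 can be read, because each value is a limit of the assay and not a number: the limit of > 100000 nM in this assay, at which 3 of the 3 values shown sit.

The compounds shown leave open whether cyclohexyl, 4-methylphenyl and cyclopropyl on the amine nitrogen differ at all in this assay.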